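This account rests on a few compounds, and the source may have more. Where it says the series, first, only, none or still open, it means among the compounds named here.

Measured in a functional assay on MCF7 cells (Homo sapiens) for cytotoxicity, read by MTT assay, with a stated time of 3 days; a higher number here means a weaker inhibitor, a lower number a stronger inhibitor:
compound 1 `C[C@H]1O[C@@H](n2cc(F)c(NC(=O)Oc3ccc(Cl)cc3)nc2=O)[C@H](O)[C@@H]1O` — 100 ug/mL
compound 2 `CCCCCOC(=O)Nc1nc(=O)n([C@@H]2O[C@H](C)[C@H]3OC(=O)O[C@H]32)cc1F` — 80 ug/mL
compound 3 `CCC(C)COC(=O)Nc1nc(=O)n([C@@H]2O[C@H](C)[C@@H](O)[C@H]2O)cc1F` — 120 ug/mL

In this assay compound 2 gives the lowest of the three numbers, but its gaps to compound 1 and to compound 3 are both within the scatter, so no order among the three is established. For the measured compounds named here, the only single-point step measured, a 1.2-fold higher number from compound 1 to compound 3 (0.08 log units; within the scatter), swaps the group on the oxygen next to a carbonyl group and is flat. Compound 4 `CC(C)CCOC(=O)Nc1nc(=O)n([C@@H]2O[C@H](C)[C@H]3OC(=O)O[C@H]32)cc1F` differs from compound 2 by isopropyl in place of propyl on a saturated chain carbon, two bonds along the chain from an oxygen next to a carbonyl group. Going by the values given here, no measured step tests chain branching at this place; the one step on the same oxygen-side group being flat, compound 4 is expected to sit near compound 2, with no change at the digits printed from compound 2 to compound 4 (within the scatter) not beyond the scatter. Compound 4 is estimated at 80 ug/mL (range 45 ug/mL to 150 ug/mL).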

Compound 4, half-maximal inhibitory concentration: 100 ug/mL
Beside the measured number, compound 4's estimate is 1.3-fold (0.10 log units) below it, within the range that was stated.
By their numbers in this assay, from the lowest: compounds 2, 1, 4 and 3 (each within the scatter of the next).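

In this assay chain branching is now tested directly on the shared core of compound 2: isopropyl in place of propyl, on a saturated chain carbon two bonds along the chain from an oxygen next to a carbonyl group, gives a 1.3-fold higher number from compound 2 to compound 4 (0.10 log units; within the scatter) and stays flat. At this position, the change leaves no readable difference in the number. No supporting measurement bears on this result.

On these data alone, whether an amine, a carboxylic acid or a longer chain in place of isopentyl would move the number beyond the scatter remains open.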